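The source may report more compounds than this note shows. Statements on the series, on what has been measured and on what is new or still open speak of the compounds shown alone.

In a functional assay on HepG2 cells (Homo sapiens) for inhibition, read by MTT assay, with a stated time of 48 h (a higher number here means a weaker inhibitor, a lower number a stronger inhibitor), compound 3 `CCOC(=O)C1=C(N/N=C(\C#N)C(N)=O)Nc2[nH]nc(C)c2C1c1ccc(N(C)C)cc1` gives 48400 nM. Compound 2 `CCOC(=O)C1=C(N/N=C(/C#N)C(=O)OCC)Nc2[nH]nc(C)c2C1c1ccc(N(C)C)cc1` gives 46400 nM and compound 1 `CCOC(=O)C1=C(N/N=C(\c2ccc([N+](=O)[O-])cc2)N2CCN(c3ccc(F)cc3)CC2)Nc2[nH]nc(C)c2C1c1ccc(N(C)C)cc1` gives 90200 nM, so compound 3 stands level with both, as all three lie within the usual scatter. Compound 4 `CCOC(=O)C(=NNC1=C(C(=O)OCC)C(c2ccc(N(C)C)cc2)c2c(C)n[nH]c2N1)C(=O)OCC` keeps the shared core and alters one part: a group of 12 heavy atoms (7 carbon, 1 nitrogen, 4 oxygen; no ring) in place of a group of 7 heavy atoms (3 carbon, 3 nitrogen, 1 oxygen; no ring), on an amine nitrogen. Going by the values given here, the one measured step that bears on this is a 1.0-fold higher number from compound 2 to compound 3 (0.02 log units; within the scatter). It also exchanged a ring-free group on that amine nitrogen, and it stayed within the scatter. No step beyond the scatter is therefore expected in this assay, and the estimated change is a 1.0-fold higher number from compound 3 to compound 4 (0.01 log units; within the scatter). For compound 4 the expected value is 50000 nM, with an estimated range of 25000 nM to 100000 nM.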

Compound 4, half-maximal inhibitory concentration: 80800 nM
Compound 4: middle estimate off by 1.6-fold (0.21 log units), on the low side; the range from low to high includes it.
By their numbers in this assay, from the lowest: compounds 2, 3, 4 and 1 (each within the scatter of the next).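

In this assay the ring-free group on the amine nitrogen now has 12 heavy atoms and 0 hydrogen-bond donors, yet the changes are small: a 1.7-fold higher number from compound 3 to compound 4 (0.22 log units; within the scatter) and a 1.7-fold higher number from compound 2 to compound 4 (0.24 log units; within the scatter) are both printed as within the scatter. Even this largest ring-free group shown therefore gives no clear change at this position. No measurement here explains this result.

As far as these compounds go, whether a group ending in a carboxylic acid or an amine would give a step beyond the scatter remains open. So does the effect of changes elsewhere on the shared core.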